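Oxetane in place of the lactam on the alkyne arm

The compounds below may be only part of what the source reports. "The series", "measured", "known", "first", "only" and "open" are said of these compounds alone.

The series shares one core, varied only at the chain on the triple-bonded carbon. Compound 1 `NC(=O)c1cc(Cl)c2c(Cl)c(C#CCO)n([C@H]3CCCNC3)c2n1` carries a hydroxy there and in a functional assay on KG-1 cells (Homo sapiens) for antiproliferative activity (a lower number here means that less compound is needed, a higher number that more compound is needed for the effect), compound 1 gives 301 nM. Compound 2 `NC(=O)c1cc(Cl)c2c(Cl)c(C#CC3COCCO3)n([C@H]3CCCNC3)c2n1` bears a dioxane ring and its repeated readings in this assay are 77 nM; 203 nM (2 entries); no single number stands for compound 2 (the several entries of compound 2 in this assay, 77 nM; 203 nM (2 entries)). Compound 3 `NC(=O)c1cc(Cl)c2c(Cl)c(C#CCN3CCCC3=O)n([C@H]3CCCNC3)c2n1` holds a 2-oxopyrrolidin-1-yl and in this assay compound 3 gives 178 nM. Within the data shown here, the only single-point step measured is a 1.7-fold lower number from compound 1 to compound 3 (0.23 log units; within the scatter), so compound 3 sits inside the scatter of compound 1, and the two readings of compound 2 bracket both.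

Compound 4 `CC1(C#Cc2c(Cl)c3c(Cl)cc(C(N)=O)nc3n2[C@H]2CCCNC2)COC1` differs from compound 3 as follows: 3-methyloxetan-3-yl in place of (2-oxopyrrolidin-1-yl)methyl on a triple-bonded carbon. Among the measured compounds shown here, no measured step exchanges the 2-oxopyrrolidin-1-yl for a four-membered ring, so the hydroxy-to-lactam step and the spread of compound 2 are the only guides, and every variation of this chain so far has stayed within a narrow band in this assay. Compound 4 is therefore expected to show a 1.1-fold higher number from compound 3 to compound 4 (0.05 log units; within the scatter), with no movement beyond the scatter. The estimate for compound 4 in this assay is 200 nM, with a range from 70 nM to 600 nM.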

Compound 4, half-maximal effective concentration: 119 nM
Compound 4: middle estimate off by 1.7-fold (0.23 log units), on the high side; the range from low to high includes it.
By their numbers in this assay, from the lowest: compounds 4, 3 and 1 (each within the scatter of the next, the first and the last beyond it).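

In this assay, the 2-oxopyrrolidin-1-yl arm on the triple-bonded carbon can give way to a smaller four-membered ring without leaving the scatter, with a 1.5-fold lower number from compound 3 to compound 4 (0.17 log units; within the scatter), so the lactam carbonyl and nitrogen are not required for a reading of this size. Among these compounds, the exchange of hydroxymethyl for 3-methyloxetan-3-yl gives the first single-number step at this position to lie beyond the scatter, though it remains modest, with a 2.5-fold lower number from compound 1 to compound 4 (0.40 log units; beyond the scatter); the chain therefore registers a measurable difference, whereas the hydroxy-to-lactam step did not, and the lactam compound 3 stays within the scatter of both ends. The dioxane compound 2 cannot be placed in this order, as it has no single number: the several entries of compound 2 in this assay, 77 nM; 203 nM (2 entries)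

The compounds shown leave open whether the difference follows the oxetane oxygen, the four-membered ring or the methyl group, which an unsubstituted oxetan-3-yl or a 1-methylcyclobutyl arm would separate. Also open is how this position responds to a chain ending in an amine or a carboxylic acid, since every arm shown is uncharged.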